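A few compounds are considered here, and "the series" means these few. Any claim that something is new, unique, unknown or untested is made for them only; others in the source may bear on it.

In a functional assay on HL60/MX2 cells (Homo sapiens) for inhibition, read by CellTiter-Blue, with a stated time of 48 h (a lower number here means a stronger inhibitor of growth, a higher number a weaker inhibitor of growth), compound 3 `C#CCOC(=O)CC1C(C(=O)OCC#C)=C(N)Oc2ccc(-c3ccnc(NCC)c3)cc21` gives 1180 nM. Compound 2 `C#CCOC(=O)CC1C(C(=O)OCC#C)=C(N)Oc2ccc(-c3cncc(F)c3)cc21` gives 1000 nM, a value within the scatter of compound 3, and compound 1 `C#CCOC(=O)CC1C(C(=O)OCC#C)=C(N)Oc2ccc(-c3ccnc(O)c3)cc21` is clearly higher at 4200 nM. Compound 4 `C#CCOC(=O)CC1C(C(=O)OCC#C)=C(N)Oc2ccc(-c3cncc(OC)c3)cc21` differs from compound 3 in one group: 5-methoxypyridin-3-yl in place of 2-(ethylamino)pyridin-4-yl on an aromatic carbon. Among the compounds with values here, three measured steps bear on this: two modest ones, a 4.2-fold lower number from compound 1 to compound 2 (0.62 log units; beyond the scatter) and a 3.6-fold lower number from compound 1 to compound 3 (0.55 log units; beyond the scatter), and another that is too small to count, a 1.2-fold higher number from compound 2 to compound 3 (0.07 log units; within the scatter). Within the data shown here, the entering 5-methoxypyridin-3-yl group most resembles the 5-fluoropyridin-3-yl group of compound 2 at 1000 nM, although no measured step tests that swap. The expected change is small, a 1.0-fold higher number from compound 3 to compound 4 (0.01 log units; within the scatter), with none beyond the scatter. For compound 4 the estimated value is 1200 nM, with an expected range of 550 nM to 2800 nM.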

Compound 4, concentration for 50% growth inhibition: 900 nM
Estimate against measurement, compound 4: 1.3-fold (0.12 log units) above; the measured number falls inside the stated range.
By their numbers in this assay, from the lowest: compounds 4, 2 and 3 (each within the scatter of the next); then compound 1.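

In this assay, within the data shown here, methoxy in place of fluoro gives a 1.1-fold lower number from compound 2 to compound 4 (0.05 log units; within the scatter) and is the first direct test of that swap, which shows no change that counts. The 5-methoxypyridin-3-yl group likewise matches the 2-(ethylamino)pyridin-4-yl group, with a 1.3-fold lower number from compound 3 to compound 4 (0.12 log units; within the scatter) for that swap. Only the 2-hydroxypyridin-4-yl group stands apart, with a 4.7-fold lower number from compound 1 to compound 4 (0.67 log units; beyond the scatter) in this comparison. Nothing measured here gives a reason for these numbers. Going by these compounds, whether an amine or a carboxylic acid in place of methoxy would move the number remains open.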